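The source may hold more compounds than are shown below. What is called first, only, known or untested is meant among the compounds shown, and "the series" means these compounds.

Working notes on the series. Compound 1 `Cc1ncc(CO)c2c(Nc3cnccn3)c(NC(C)(C)C)oc12` is reported in a functional assay on HEK293 cells for agonist activity at Toll-like receptor 8 (Homo sapiens), read by reporter gene assay (on this read-out higher numbers stand for an effect only at larger amounts of compound and lower numbers for an effect already at smaller amounts), as "not active" (no number reported), without a number. Compound 2 `CCCCCNc1oc2c(C)ncc(CO)c2c1Nc1ccccc1` gives 2250 nM in this assay. Compound 3 `Cc1ncc(CO)c2c(Nc3ccccn3)c(NC[Si](C)(C)C)oc12` gives 4990 nM in this assay, the higher of the two numbers available; the gap to compound 2 lies beyond the usual scatter, so compound 3 stands as the weaker of the two compounds with numbers, with compound 1 reported without a value.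

Compound 4 `CCCCNc1oc2c(C)ncc(CO)c2c1Nc1ccccn1` is not yet measured. It differs from compound 3 in one place: a group of 3 heavy atoms (3 carbon; no ring) in place of a group of 4 heavy atoms (3 carbon, 1 silicon; no ring), on a saturated chain carbon bound to a nitrogen on an aromatic ring. Going by the values given here, no step between measured compounds isolates this kind of exchange, so the data give no direct guide. Compound 2, which also carries a plain saturated chain at this position, gives 2250 nM, which argues against a large rise. A small step, either direction, is expected, most likely within the scatter: a 1.4-fold lower number from compound 3 to compound 4 (0.15 log units; within the scatter) is the estimated change. Compound 4 is estimated at 3500 nM, with a range from 1200 nM to 10000 nM.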

Compound 4, half-maximal effective concentration: 9380 nM
The estimate for compound 4 lay 2.7-fold (0.43 log units) below the measured number, and the stated range covers the measured number.
By their numbers in this assay, from the lowest: compound 2; then compounds 3 and 4 (each within the scatter of the next).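

In this assay, the exchange on a saturated chain carbon bound to a nitrogen on an aromatic ring now has its first direct reading: propyl in place of the group of 4 heavy atoms that carries silicon gives a 1.9-fold higher number from compound 3 to compound 4 (0.27 log units; within the scatter) and stays within the scatter. Going by these compounds alone, at this place, the silicon-bearing group and the all-carbon propyl group therefore cannot be told apart on this read-out, a comparison that the earlier compounds, which differ in more than one place, could not offer. No measurement at hand bears on why the two groups read alike.

A single step at this place says nothing about how a longer chain, a cyclohexyl ring or a terminal amine would read here. Going by these compounds, whether the same exchange would read alike with another aromatic ring on the second nitrogen of the shared core also remains open.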